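Pyrazol-4-yl in place of pyridin-4-yl: efficacy expectation

The compounds below may be only part of what the source reports. "The series", "measured", "known", "first", "only" and "open" are said of these compounds alone.

Of the compounds shown here, two have been measured in an in vitro functional assay on HEK285-7 cells for antagonist activity at prostaglandin D2 receptor 2 (Homo sapiens), read by BRET and beta-arrestin recruitment; on this read-out lower numbers stand for smaller maximal responses and higher numbers for larger maximal responses. Compound 1 `O=C(O)Cc1sc(C(c2ccc(F)cc2)c2ccc(F)cc2)nc1-c1ccnc(N2CCCC2)c1` gives 80%. Compound 2 `O=C(O)Cc1sc(C(c2ccc(F)cc2)c2ccc(F)cc2)nc1-c1ccncc1` gives 80%; the step of no change at the digits printed from compound 1 to compound 2 (within the scatter) shows that compound 2 stands level with compound 1 at the digits shown, within the scatter.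

Compound 3 `O=C(O)Cc1sc(C(c2ccc(F)cc2)c2ccc(F)cc2)nc1-c1cn[nH]c1` has not been measured. Its difference from compound 2 is 1H-pyrazol-4-yl in place of pyridin-4-yl on an aromatic carbon. The entering group sits on an aromatic carbon of a five-membered aromatic ring with one nitrogen and one sulfur, two ring bonds from the ring sulfur.

For the measured compounds named here, only one measured step bears on this change: no change at the digits printed from compound 1 to compound 2 (within the scatter), which took pyrrolidin-1-yl off the pyridin-4-yl group without moving the maximal response beyond the scatter. Going by the values given here, no measured step exchanges the six-membered ring itself, so the expectation rests on that single step and on the fact that both measured compounds sit at the same level. In this assay the maximal response of compound 3 is expected to stay close to that of compound 2, a number 2 percentage points lower from compound 2 to compound 3 (within the scatter), with a wider range kept for the untested ring exchange. Compound 3 is therefore estimated at 78%, between 60% and 95%.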

Compound 3, largest response reached (reported as efficacy), in percent of the reference or control that the assay uses: 80%
Compound 3: middle estimate off by 2 percentage points, on the low side, within the range that was stated.
By their numbers in this assay, from the lowest: compounds 1, 2 and 3 (each within the scatter of the next).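

In this assay, replacing the whole pyridin-4-yl ring with 1H-pyrazol-4-yl gives no change at the digits printed from compound 2 to compound 3 (within the scatter), so the level seen so far is not tied to a six-membered ring at this aromatic carbon: a five-membered aromatic ring with one more ring nitrogen and a hydrogen-bond donor that pyridin-4-yl lacks fits the same level. The earlier comparison covered only removal of pyrrolidin-1-yl from the pyridin-4-yl group, whereas the larger exchange of 2-(pyrrolidin-1-yl)pyridin-4-yl for 1H-pyrazol-4-yl gives no change at the digits printed from compound 1 to compound 3 (within the scatter) and likewise stays within the scatter in this read-out. Nothing available explains why these three groups leave the maximal response level.

Going by these compounds, all three compounds share one level, so it remains open whether any group on this carbon can move the maximal response, for example a phenyl ring with no ring nitrogen, 1-methyl-1H-pyrazol-4-yl, or a small alkyl chain in place of a ring. Potency at the receptor also stays open, since the values here describe only the largest response reached.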